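From methyl to chloro: compound 2 to compound 4

This account rests on a few compounds, and the source may have more. Where it says the series, first, only, none or still open, it means among the compounds named here.

Measured so far in a toxicity assay on THP-1 cells (Homo sapiens) for inhibition (on this read-out higher numbers stand for lower toxicity in this test and lower numbers for higher toxicity in this test), each value being a limit of the assay and not a number:
- compound 1 `COc1ccc(-c2cnc(NC(=O)c3ccccc3O)n2C)cc1`: > 100000 nM
- compound 2 `Cc1cccc(C(=O)Nc2ncc(-c3ccccc3)n2C)c1`: > 50000 nM
- compound 3 `COc1ccc(-c2cnc(NC(=O)c3cccc(C)c3)n2C)cc1`: > 100000 nM

Compound 2 has only a limit, (the limit of > 50000 nM in this assay, at which 1 of the 3 values shown sits). Compound 1 and compound 3 likewise have only a limit, (the limit of > 100000 nM in this assay, at which 2 of the 3 values shown sit).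

Compound 4 `Cn1c(-c2ccccc2)cnc1NC(=O)c1cccc(Cl)c1` keeps the core of compound 2 and alters one group: chloro in place of methyl on an aromatic carbon. In words, this is chloro in place of methyl on an aromatic carbon, turning 3-methylphenyl into 3-chlorophenyl.

For the measured compounds named here, two measured steps bear on this change: a step that the two limits leave unreadable from compound 1 to compound 3 and a step that the two limits leave unreadable from compound 2 to compound 3. Neither has a size that can be read, so neither offers a measured guide to how far a group swap moves the value. Compound 2 at > 50000 nM remains the nearest reference, so no step beyond the scatter is expected in this assay, in either direction. The estimated step is a step that the limit leaves unreadable from compound 2 to compound 4. For compound 4 the expected value is 60000 nM, with an estimated range from 25000 nM to 100000 nM. A further limit instead of a number would be no surprise.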

Compound 4, half-maximal cytotoxic concentration: > 50000 nM
Compound 4: no number, only a limit (the forecaster's own chance of this, stated with the estimate: 80%); the middle value does not contradict the limit.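

In this assay, both compound 2 and compound 4 are limits of the assay and not numbers, and no step between them can be read: the limit of > 50000 nM in this assay, at which 2 of the 4 values shown sit.

The compounds shown leave open whether 3-chlorophenyl and 3-methylphenyl differ at all in this assay.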